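This account rests on a few compounds, and the source may have more. Where it says the series, first, only, none or still open, it means among the compounds named here.

Three compounds built on one shared core have been examined in an ADME assay on HepG2 2.2.15 cells (Homo sapiens) for cytotoxicity; on this read-out lower numbers stand for higher toxicity in this test and higher numbers for lower toxicity in this test. Compound 1 `CC(C)(C)OC(=O)Nc1ncc(C(Oc2ccc(Br)cc2)c2ccc(Cl)cc2)s1` reaches only the limit of > 50000 nM, which is a boundary of the measurement rather than a number. Compound 2 `CC(C)(C)OC(=O)Nc1ncc(C(Oc2ccc(F)c(Cl)c2)c2ccc(Cl)cc2)s1` likewise stops at the limit of > 50000 nM. Compound 3 `COCCc1ccc(OC(c2ccc(Cl)cc2)c2cnc(NC(=O)OC(C)(C)C)s2)cc1` also gives only the limit of > 50000 nM. Compound 3 therefore stands exactly where the other two sit, at the limit of > 50000 nM in this assay, at which 3 of the 3 values shown sit. The measured steps a step that the two limits leave unreadable from compound 1 to compound 2, a step that the two limits leave unreadable from compound 1 to compound 3 and a step that the two limits leave unreadable from compound 2 to compound 3 are all unreadable in size, since each has a limit at both ends.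

Compound 4 `CC(C)(C)OC(=O)Nc1ncc(C(Oc2ccc(OCc3ccccc3)cc2)c2ccc(Cl)cc2)s1` differs from compound 3 by benzyloxy in place of 2-methoxyethyl on an aromatic carbon. Among the measured compounds shown here, no measured step bears directly on this exchange, and none of the three recorded steps has a readable size, so no direction beyond the scatter can be drawn from them. With every related compound sitting at the same limit, compound 4 is expected to remain at or near that limit, estimated at 50000 nM in this assay with a range from 20000 nM to 100000 nM. The expected step is therefore a number no higher from compound 3 to compound 4 (the limit leaves the size open).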

Compound 4, half-maximal cytotoxic concentration: > 50000 nM
Compound 4 gave a limit, no number; the forecaster's own chance of this, stated with the estimate: 70%; the middle value sits exactly at the limit.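

Compound 4, like compound 3 and compound 1, gives only a limit and no number in this assay, so neither of its two new steps can be read: the limit of > 50000 nM in this assay, at which 4 of the 4 values shown sit.

The compounds shown leave open whether any of these group exchanges changes the result in this assay at all.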